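Two Measured Compounds and a Nitro Analogue Awaited

The source may report more compounds than this note shows. Statements on the series, on what has been measured and on what is new or still open speak of the compounds shown alone.

Compound 1 `Cc1cc(O)cc(C)c1-c1nc2c(=O)n(C)c(=O)n(C)c2[nH]1`: in an assay for binding affinity to adenosine receptor A1 (Bos taurus) (a lower number here means a stronger inhibitor, a higher number a weaker inhibitor), compound 1 gives 30 nM.
Compound 2 `Cn1c(=O)c2nc(-c3ccc(-c4ccccc4)cc3)[nH]c2n(C)c1=O`: in this assay compound 2 gives 3.5 nM.

Compound 2 holds the lowest of the two numbers; compound 1 sits above it, and the gap between them lies beyond the usual scatter. Compound 3 `Cn1c(=O)c2nc(-c3ccc([N+](=O)[O-])cc3)[nH]c2n(C)c1=O` differs from compound 2 in one place: nitro in place of phenyl on an aromatic carbon. Among the measured compounds shown here, no step between measured compounds matches this change, so the expectation rests on compound 2 alone. In this assay a moderate rise in the number is expected, estimated as a 5.7-fold higher number from compound 2 to compound 3 (0.76 log units; beyond the scatter). Compound 3 is expected to give 20 nM in this assay, within a range from 5 nM to 80 nM.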

Compound 3, half-maximal inhibitory concentration: 8 nM
For compound 3 the middle estimate is 2.5-fold (0.40 log units) above the measured one, within the range that was stated.
By their numbers in this assay, from the lowest: compound 2; then compound 3; then compound 1.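

Replacing phenyl with nitro on this aromatic carbon gives, in this assay, a 2.3-fold higher number from compound 2 to compound 3 (0.36 log units; beyond the scatter). The position therefore holds a low number with a group of three heavy atoms and no ring as well as with one of six heavy atoms and a ring, so the outer phenyl ring is not required for a number of this order. Nothing at hand accounts for the size of this step.

Going by these compounds, it remains open whether an amine or a carboxylic acid on this carbon would stay close to compound 3 at 8 nM. On these data alone, how a methoxy group would compare with nitro and phenyl is also open.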